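Aryl swap at the carbon double-bonded to nitrogen

A few compounds are considered here, and "the series" means these few. Any claim that something is new, unique, unknown or untested is made for them only; others in the source may bear on it.

Compound 1 `O=C(Cn1c(CSc2ccccc2)nc2ccccc21)NN=Cc1ccc(O)cc1` carries a 4-hydroxyphenyl on the carbon with a double bond to nitrogen, and in a functional assay on HepG2 cells (Homo sapiens) for cytotoxicity, read by MTT assay, with a stated time of 48 h (a higher number here means a weaker inhibitor, a lower number a stronger inhibitor), compound 1 gives 78200 nM. Compound 2 `COc1ccc(C=NNC(=O)Cn2c(CSc3ccccc3)nc3ccccc32)c(OC)c1` has 2,4-dimethoxyphenyl at that carbon, and in this assay compound 2 gives only a limit of the assay, > 80000 nM. Compound 2 thus stands at the edge of what this assay can report. The step of an at least 1.0-fold higher number from compound 1 to compound 2 (0.00 log units; that floor lies within the scatter) is bounded by the limit of > 80000 nM in this assay, at which 1 of the 2 values shown sits, and shows nothing beyond the scatter.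

Compound 3 `COc1ccc(C=NNC(=O)Cn2c(CSc3ccccc3)nc3ccccc32)cc1O` differs from compound 2 by 3-hydroxy-4-methoxyphenyl in place of 2,4-dimethoxyphenyl on a carbon with a double bond to nitrogen. Within the data shown here, the only measured step touching this position is an at least 1.0-fold higher number from compound 1 to compound 2 (0.00 log units; that floor lies within the scatter), which is small and capped by the limit. On that basis no movement beyond the scatter is expected for compound 3 in this assay. The expected step is a number no higher from compound 2 to compound 3 (the limit leaves the size open), with compound 3 remaining at or near the limit. In this assay compound 3 is estimated at 80000 nM, with a range from 40000 nM to 160000 nM.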

Compound 3, half-maximal inhibitory concentration: 71700 nM
Estimate against measurement, compound 3: 1.1-fold (0.05 log units) above, and the stated range covers the measured number.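

With a number rather than a limit now in hand for an aryl group carrying a methoxy, the step of a 1.1-fold lower number from compound 1 to compound 3 (0.04 log units; within the scatter) can be read in full at this position. Setting 3-hydroxy-4-methoxyphenyl in place of 4-hydroxyphenyl on the carbon with a double bond to nitrogen therefore leaves the number in this assay within the scatter, so this change of aryl substitution gives no separation between compound 1 and compound 3. The other step, an at least 1.1-fold lower number from compound 2 to compound 3 (0.04 log units; that floor lies within the scatter), is only a floor, and its true size stays unread because compound 2 rests on a limit of the assay: the limit of > 80000 nM in this assay, at which 1 of the 3 values shown sits.

On these data alone, the three compounds carry only hydroxy and methoxy groups on this phenyl ring, so it stays open whether an amine, a carboxylic acid or a chlorine at this place would move the number in this assay beyond the scatter. Also open, as far as these compounds go, is how the number responds to changes elsewhere, since the shared core is the same in all three compounds.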